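A few compounds are considered here, and "the series" means these few. Any claim that something is new, unique, unknown or untested is made for them only; others in the source may bear on it.

In a functional assay on DU-145 cells (Homo sapiens) for inhibition, read by trypan blue exclusion, with a stated time of 96 h (a lower number here means a stronger inhibitor of growth, a higher number a weaker inhibitor of growth), three compounds of the series have numbers. Compound 1 (`COc1ccccc1/C=C(/SCc1ccc(F)cc1)C(=O)c1ccc(Br)cc1`) gives 10000 nM and compound 2 (`O=C(/C(=C\c1ccc(O)cc1)SCc1ccc(Cl)cc1)c1ccc(Br)cc1`) gives 10000 nM in the same read-out. Compound 3 (`O=C(/C(=C\c1ccc(Br)cc1)SCc1ccc(F)cc1)c1ccc(Br)cc1`) gives 25000 nM as the highest of the three numbers, beyond the scatter from both others.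

The move to compound 4 (`O=C(/C(=C\c1ccc(O)cc1)SCc1ccc(F)cc1)c1ccc(Br)cc1`) is hydroxy in place of bromo on an aromatic carbon and puts hydroxy in place of bromo on an aromatic carbon. Going by the values given here, the one measured step at this site is a 2.5-fold higher number from compound 1 to compound 3 (0.40 log units; beyond the scatter) on 4-bromophenyl replacing 2-methoxyphenyl, and it is modest. Compound 2 at 10000 nM already carries 4-hydroxyphenyl, but it also differs from compound 4 elsewhere, so its support is indirect.

A modest step toward a lower number is therefore expected in this assay on the strength of these two compounds. The estimated step is a 2.5-fold lower number from compound 3 to compound 4 (0.40 log units; beyond the scatter) and nothing larger is expected. For compound 4 the estimate is 10000 nM with 5000 nM to 20000 nM as the expected range.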

Compound 4, concentration for 50% growth inhibition: 10000 nM
Estimate against measurement, compound 4: no gap at the digits printed, and the stated range covers the measured number.
By their numbers in this assay, from the lowest: compounds 1, 2 and 4 (each within the scatter of the next); then compound 3.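

In this assay, going by these compounds alone, hydroxy in place of bromo on an aromatic carbon para to a large group gives a 2.5-fold lower number from compound 3 to compound 4 (0.40 log units; beyond the scatter) with the rest of the molecule unchanged, the first direct reading of this exchange at this position. Fluoro in place of chloro gives no change at the digits printed from compound 2 to compound 4 (within the scatter) and 4-hydroxyphenyl in place of 2-methoxyphenyl gives no change at the digits printed from compound 1 to compound 4 (within the scatter) in the same read-out, so neither exchange separates these pairs, and among the single-place steps only those involving the 4-bromophenyl of compound 3 lie beyond the scatter. No measured evidence bears on the reason for the bromo to hydroxy step.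

Going by these compounds, whether an amine or a carboxylic acid at this position would move the number beyond the scatter from compound 4 remains open. Also open, on these data alone, is whether the bromo to hydroxy step carries over to compounds bearing chloro, as compound 2 does.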